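Methyl to fluoro, starting from compound 3

A few compounds are considered here, and "the series" means these few. Any claim that something is new, unique, unknown or untested is made for them only; others in the source may bear on it.

Compound 1 (`O=C(Nc1ccc(O)cc1)c1cc(Cl)ccc1O`) gives 33.1 10^-6 cm/s in an ADME assay for permeability, using PAMPA, with a stated time of 3 h (a lower number here means that the compound crosses the layer more slowly, a higher number that the compound crosses the layer faster), and compound 2 (`O=C(Nc1ccc(N2CCCCC2)cc1)c1cc(Cl)ccc1O`) gives 43.3 10^-6 cm/s in the same measurement. Compound 3 (`Cc1ccc(O)c(C(=O)Nc2ccc([N+](=O)[O-])cc2Cl)c1`) gives 20.9 10^-6 cm/s and so sits within the scatter of compound 1 but beyond the scatter below compound 2. Compound 4 (`O=C(Nc1ccc([N+](=O)[O-])cc1Cl)c1cc(F)ccc1O`) differs from compound 3 by fluoro in place of methyl on an aromatic carbon in one place: fluoro in place of methyl on an aromatic carbon, para to a hydroxy group. Within the data shown here, the only measured step (a 1.3-fold higher number from compound 1 to compound 2 (0.12 log units; within the scatter)) is a different exchange, piperidin-1-yl in place of hydroxy, and it stays within the scatter. Among the measured compounds shown here, with that step as the only guide, the change (a 1.0-fold lower number from compound 3 to compound 4 (0.02 log units; within the scatter)) is expected to stay within the scatter, with no direction favoured. Compound 4 is estimated at 20 10^-6 cm/s with 11 10^-6 cm/s to 36 10^-6 cm/s as its expected range.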

Compound 4, apparent permeability: 30.7 10^-6 cm/s
Estimate against measurement, compound 4: 1.5-fold (0.19 log units) below; low and high end bracket the measured number.
By their numbers in this assay, from the lowest: compounds 3, 4, 1 and 2 (each within the scatter of the next, the first and the last beyond it).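

Fluoro in place of methyl on this aromatic carbon, para to a hydroxy group, gives a 1.5-fold higher number from compound 3 to compound 4 (0.17 log units; within the scatter) in this assay and thus gives this position a measured step of its own, which the earlier compounds did not. For this one pair, exchanging one heavy atom for another, with no hydrogen-bond donor or acceptor leaving or entering, stays within the scatter. Nothing at hand accounts for the size of this step.

As far as these compounds go, whether an amine, a carboxylic acid or a longer chain at this position would also stay within the scatter remains open. So does whether fluoro in place of methyl gives a similar step on another core.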